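The source may report more compounds than this note shows. Statements on the series, on what has been measured and on what is new or still open speak of the compounds shown alone.

Two compounds have been measured in a functional assay on CHO cells with adenosine receptor A1 (Homo sapiens) as the target, read by cAMP accumulation and immunoassay, with a stated time of 6 min, tested at 0.01 uM; a higher number here means a weaker effect of the compound at the concentration tested, a lower number a stronger effect:

- compound 1, `Nc1scc(CN2CCN(c3cccc(F)c3)CC2)c1C(=O)c1cccc(C(F)(F)F)c1`, gives -11%
- compound 2, `Nc1scc(CN2CCN(C3CCCCCC3)CC2)c1C(=O)c1ccc(Cl)cc1`, gives 2.9%

Compound 2 has the higher of these two readings, and compound 1 lies lower than it by a gap that goes beyond the usual scatter of this kind of measurement. Even so, both readings are small, so neither compound shows much of an effect at the concentration tested.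

Compound 3, `Nc1scc(CN2CCN(c3cccc(F)c3)CC2)c1C(=O)c1ccc(Cl)cc1`, has not yet been measured. It keeps the rest of compound 2 unchanged and alters only the group on the amine nitrogen in a ring: 3-fluorophenyl in place of cycloheptyl on an amine nitrogen in a ring. Among the measured compounds shown here, the group that enters is the one compound 1 carries in this place, but compound 1 also differs from compound 3 elsewhere, so the measured pair gives no clean reading of this single change on its own. With both known readings close to zero, the step in this assay is expected to be small, in no clear direction, and most likely within the usual scatter. The reading of compound 3 is estimated at -3%, with a likely range from -20% to 14%. That estimate means an expected step of a number 5.9 percentage points lower from compound 2 to compound 3 (within the scatter).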

Compound 3, a percentage reported as activity, at one concentration (the size of the read-out at that concentration, not a potency): -18%
Compound 3: the middle estimate sits 15 percentage points above what was measured; low and high end bracket the measured number.
By their numbers in this assay, from the lowest: compounds 3 and 1 (each within the scatter of the next); then compound 2.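

In this assay, the group on the amine nitrogen of the six-membered non-aromatic ring with 2 nitrogen turns out to matter: 3-fluorophenyl in place of cycloheptyl gives a number 20.9 percentage points lower from compound 2 to compound 3 (beyond the scatter), a clean single change that the two earlier compounds could not provide, made between two groups with the same count of heavy atoms. The other single change, 4-chlorophenyl in place of 3-(trifluoromethyl)phenyl on a carbonyl carbon, gives a number 7 percentage points lower from compound 1 to compound 3 (within the scatter), so at this one concentration these two groups cannot be told apart. No measurement available here accounts for either step.

The compounds shown leave open whether the step on the amine nitrogen follows the aromatic ring itself or its fluorine, and a plain phenyl group at that place would separate the two. They also leave open how an open carbon chain such as n-butyl would read there, and how far these single-concentration readings reflect potency, which only a full concentration series could show.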